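Exchanging a hexyl urea tail for a benzyl one

The compounds below may be only part of what the source reports. "The series", "measured", "known", "first", "only" and "open" are said of these compounds alone.

Four compounds share the same acylguanidine motif joined to an aminothiazole-bearing fragment. Compound 1 `N/C(=N\C(=O)NC1CCCCC1)Nc1cccc(-c2csc(N)n2)c1` carries the aminothiazole on a phenyl ring and a cyclohexyl urea, and in a functional assay on HEK293T cells for agonist activity at histamine H2 receptor (Homo sapiens), read by beta-arrestin recruitment (on this read-out lower numbers stand for smaller maximal responses and higher numbers for larger maximal responses), compound 1 gives "not determined" (no result reported). Compound 2 `Cc1nc(N)sc1CCCN/C(N)=N/C(=O)NC1CCCCC1` places the aminothiazole on a short chain with the same cyclohexyl urea, and in this assay compound 2 gives 0.43. Compound 3 `CCCCCCNC(=O)/N=C(\N)NC1CCc2nc(N)sc2C1` fuses the aminothiazole into a bicyclic saturated core and carries a hexyl urea; in this assay compound 3 gives "not determined" (no result reported), so where it stands among these compounds is not known. Compound 4 `N/C(=N\C(=O)NCc1ccccc1)NC1CCc2nc(N)sc2C1` keeps the bicyclic core of compound 3 and differs from it in one place: phenyl in place of pentyl on a saturated chain carbon bound to an amide-type nitrogen. Within the data shown here, neither compound 1 nor compound 3 has a number, so the only anchor is compound 2. No step in this assay has been measured between any pair of these compounds. Among the measured compounds shown here, the direction and size of the step from compound 3 to compound 4 therefore cannot be read from the data, and any expectation must lean on the single value of compound 2. On that basis compound 4 is expected to give an intrinsic activity near 0.45, estimated to lie between 0.2 and 0.8.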

Compound 4, intrinsic activity: the largest response reached, as a fraction of the reference agonist's: 0.31
Estimate against measurement, compound 4: 0.14 above; measured number inside the range.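

Compound 3 has no single number in this assay and so compound 4 (0.31) cannot be set against it, which means no step can be read for the change from hexyl to benzyl. Nothing at hand bears on this result. Still open, going by these compounds, is whether benzyl in place of hexyl raises, lowers or leaves unchanged the maximal response.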